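The source may hold more compounds than are shown below. What is called first, only, known or untested is meant among the compounds shown, and "the series" means these compounds.

Three compounds built on the same core have been examined in an ADME assay on HepG2 2.2.15 cells (Homo sapiens) for cytotoxicity; on this read-out higher numbers stand for lower toxicity in this test and lower numbers for higher toxicity in this test. Compound 1 `Clc1ccc(C(Oc2ccc3cc(Br)ccc3c2)c2cnc(NCC3CCCCC3)s2)cc1` is reported as "not toxic" (no number reported), and compound 2 `Clc1ccc(C(Oc2ccc3cc(Br)ccc3c2)c2cnc(NCC3CCOCC3)s2)cc1` likewise as "not toxic" (no number reported). For compound 3 `CCCCCC(=O)Nc1ncc(C(Oc2ccc3cc(Br)ccc3c2)c2ccc(Cl)cc2)s1` the result is a limit of the assay rather than a number, namely > 50000 nM. That is where compound 3 stands: at the limit (the limit of > 50000 nM in this assay, at which 1 of the 3 values shown sits), with no single number to compare against. Compound 4 `O=C(Nc1ncc(C(Oc2ccc3cc(Br)ccc3c2)c2ccc(Cl)cc2)s1)C1CCOCC1` has not been measured; it differs from compound 3 by oxan-4-yl in place of pentyl on a carbonyl carbon. No measured step between any two of these compounds is available, so the expected change is none beyond the usual scatter in this assay. Compound 4 is expected to give 60000 nM, with a range from 30000 nM to 150000 nM. The step this expectation means is a step that the limit leaves unreadable from compound 3 to compound 4, expected to stay within scatter.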

Compound 4, half-maximal cytotoxic concentration: "not toxic" (no number reported)
The entry for compound 4 holds no number; the estimate stays without a comparison.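

Within the data shown here, no step from compound 3 to compound 4 can be read, as neither entry is a single number. The compounds shown leave open whether oxan-4-yl in place of pentyl changes the result in this assay at all.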